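Replacing the Aryl Hydrazone Arm of a Semicarbazone Anticonvulsant

A few compounds are considered here, and "the series" means these few. Any claim that something is new, unique, unknown or untested is made for them only; others in the source may bear on it.

Measured so far:
compound 1, `C/C(=N\NC(=O)Nc1ccc(Br)cc1)c1ccc(O)cc1`, 300 mg/kg;
compound 2, `O=c1snc(Nc2ncccn2)n1-c1ncccn1`, 300 mg/kg;
compound 3, `CCOc1ccc(NC(=O)N/N=C(\C)c2ccc(O)cc2)cc1`, 100 mg/kg.

All three were tested in a functional assay on the whole organism with Mus musculus as the target, in the maximal electroshock model, with a stated time of 0.5 h; a lower number here means that less compound is needed, a higher number that more compound is needed for the effect. Compound 3 gives the lowest number of the three; compound 1 and compound 2 both sit at the same higher number. Within the data shown here, the one measured step, a 3.0-fold lower number from compound 1 to compound 3 (0.48 log units; beyond the scatter), concerns only the group on the aromatic ring of the urea side.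

The unmeasured compound 4, `CCOc1ccc(NC(=O)N/N=C(\C)CC(C)C)cc1`, keeps that ethoxy ring and changes the other end: isobutyl in place of 4-hydroxyphenyl on a carbon with a double bond to nitrogen. Among the measured compounds shown here, no measured step touches this position, so the data give no direction. The expectation is therefore a step of a 3.0-fold higher number from compound 3 to compound 4 (0.48 log units; beyond the scatter), roughly back toward the level of compound 1, with a wide range. Compound 4 is estimated at 300 mg/kg, between 100 mg/kg and 1000 mg/kg.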

Compound 4, minimum effective dose: 100 mg/kg
Beside the measured number, compound 4's estimate is 3.0-fold (0.48 log units) above it; measured number inside the range.
By their numbers in this assay, from the lowest: compounds 3 and 4 (each within the scatter of the next); then compounds 1 and 2 (each within the scatter of the next).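

In this assay, isobutyl in place of 4-hydroxyphenyl on a carbon with a double bond to nitrogen gives no change at the digits printed from compound 3 to compound 4 (within the scatter). This position therefore accepts a group with no ring and no hydrogen-bond donor or acceptor, and in this pair 4-hydroxyphenyl is not needed to keep the number. Nothing shown here explains why the two groups read alike. Still open, from the compounds shown here alone, is whether an amine, a carboxylic acid or a longer chain in this place would keep the number, and whether isobutyl would do the same alongside the bromo ring of compound 1.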